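Adding a Trifluoromethyl to a Chlorophenyl Furoate Ester

The compounds below may be only part of what the source reports. "The series", "measured", "known", "first", "only" and "open" are said of these compounds alone.

Measured compounds:
compound 1 `COc1cc(COC(=O)c2ccco2)cc(OC)c1OC` gives 10%
compound 2 `COc1cc(COC(=O)c2ccc(-c3ccccc3C(F)(F)F)o2)cc(OC)c1OC` gives 54.9%
compound 3 `COc1cc(COC(=O)c2ccc(-c3ccccc3Cl)o2)cc(OC)c1OC` gives 34.6%

All three were tested in an assay on isolated protein for inhibition of high affinity 3',5'-cyclic-AMP phosphodiesterase 7A (Homo sapiens), read by scintillation proximity assay and cAMP accumulation, with a stated time of 20 min, tested at 10 uM; a lower number here means less inhibition, a higher number more inhibition at the concentration tested (going by the name of the read-out). Compound 3 stands second highest of the three numbers: against the top value there is the step of a number 20.3 percentage points lower from compound 2 to compound 3 (beyond the scatter), and against the lowest value the step of a number 24.6 percentage points higher from compound 1 to compound 3 (beyond the scatter). Compound 4 `COc1cc(COC(=O)c2ccc(-c3cc(C(F)(F)F)ccc3Cl)o2)cc(OC)c1OC` differs from compound 3 by trifluoromethyl in place of hydrogen on an aromatic carbon.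

Within the data shown here, two measured steps bear on this. The step of a number 44.9 percentage points higher from compound 1 to compound 2 (beyond the scatter) shows that a trifluoromethyl-bearing phenyl on the furan raised inhibition by a large amount, and a number 20.3 percentage points lower from compound 2 to compound 3 (beyond the scatter) shows that replacing that trifluoromethyl with chloro cost a modest amount. Among the measured compounds shown here, no measured step places a trifluoromethyl onto a ring that already carries chloro, so the expectation is indirect: since compound 2 gives 54.9% with a trifluoromethyl present, a modest rise for compound 4 is expected, and the estimated step is a number 13.4 percentage points higher from compound 3 to compound 4 (beyond the scatter). Compound 4 is therefore estimated at 48%, within a range from 30% to 66%.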

Compound 4, a percentage reported as inhibition, at one concentration (the size of the read-out at that concentration, not a potency): 8%
Compound 4: middle estimate off by 40 percentage points, on the high side; the whole stated range lies above it.
By their numbers in this assay, from the lowest: compounds 4 and 1 (each within the scatter of the next); then compound 3; then compound 2.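

At this place on the chlorophenyl ring, meta to a large group and para to a chloro group, adding trifluoromethyl lowers the number in this assay: the result is a number 26.6 percentage points lower from compound 3 to compound 4 (beyond the scatter) and it undoes the gain that compound 3 held over compound 1. A trifluoromethyl on the phenyl ring therefore does not bring inhibition by itself, as compound 2 alone might have suggested. Compound 4 carries one, yet its number lies within the scatter of that of compound 1, which has neither the phenyl ring nor its groups.

Still open, as far as these compounds go, is how a methyl, a methoxy, an amine or a carboxylic acid at this same place would compare with the hydrogen of compound 3. No measurement of any property of these compounds is available to account for the drop.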